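This account rests on a few compounds, and the source may have more. Where it says the series, first, only, none or still open, it means among the compounds named here.

Working notes on the series, read in a functional assay on MCF7 cells (Homo sapiens) for antiproliferative activity, read by MTT assay, with a stated time of 72 h; on this read-out lower numbers stand for stronger inhibition and higher numbers for weaker inhibition. Compound 1 (`CCN(CC)CCNC(=O)c1ccc(C(CC)(CC)c2ccc(OCC(O)C(C)(C)C)c(C)c2)n1CC`) gives 1370 nM, and compound 2 (`CCN(CC)CCCNC(=O)c1ccc(C(CC)(CC)c2ccc(C#CC(O)(CC)CC)c(C)c2)n1CC`) gives 17800 nM. For compound 3 (`CCn1c(C(=O)On2nnc3ccccc32)ccc1C(CC)(CC)c1ccc(C#CC(O)(CC)CC)c(C)c1`) the read-out is > 50000 nM, which is a limit and not a number. Compound 3 therefore has no exact position and stands at the limit of > 50000 nM in this assay, at which 1 of the 3 values shown sits.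

Compound 4 (`CCn1c(C(=O)N[C@H](C(=O)O)C(C)C)ccc1C(CC)(CC)c1ccc(C#CC(O)(CC)CC)c(C)c1`) changes the same carbonyl carbon, bringing in (1-carboxy-2-methylpropyl)amino: a group of 8 heavy atoms (5 carbon, 1 nitrogen, 2 oxygen; no ring) in place of a group of 10 heavy atoms (6 carbon, 3 nitrogen, 1 oxygen; one five-membered aromatic ring with 3 hetero atoms, one six-membered aromatic ring of carbon only), on a carbonyl carbon. Among the compounds with values here, one measured step bears on this place: an at least 2.8-fold higher number from compound 2 to compound 3 (0.44 log units; beyond the scatter). That step lies beyond the scatter, but it ends at a limit, so its true size is open. Within the data shown here, compound 2, at 17800 nM, is the nearest amide with a number, yet no measured compound carries a carboxy group at this place. Only a modest move towards lower numbers in this assay is therefore expected, and a result that stays at the limit would be no surprise. The expected step is an at least 1.4-fold lower number from compound 3 to compound 4 (0.15 log units; that floor lies within the scatter). Compound 4 is estimated at 35000 nM, with an expected range of 12000 nM to 50000 nM.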

Compound 4, half-maximal inhibitory concentration: 13000 nM
Estimate against measurement, compound 4: 2.7-fold (0.43 log units) above, within the range that was stated.
By their numbers in this assay, from the lowest: compound 1; then compounds 4 and 2 (each within the scatter of the next). At a limit, above all of these: compound 3.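

The new step on the carbonyl carbon, an at least 3.8-fold lower number from compound 3 to compound 4 (0.58 log units; beyond the scatter), shows that the read-out at this place responds to the group carried there, and that an amide bearing 1-carboxy-2-methylpropyl on its nitrogen gives a measurable value. Within the data shown here, the step of a 1.4-fold lower number from compound 2 to compound 4 (0.14 log units; within the scatter) is the first comparison of two amide-type nitrogen groups at this place, and it does not separate 1-carboxy-2-methylpropyl from 3-(diethylamino)propyl, although one carries a carboxy group and the other a tertiary amine. The size of the first step stays open, as the value for compound 3 is a limit and not a number: the limit of > 50000 nM in this assay, at which 1 of the 4 values shown sits.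

Going by these compounds, whether a methyl ester in place of the carboxylic acid, or a shorter carboxymethyl group, would give a similar value remains open. Compound 1 differs from the others in more than one place, so its value cannot be assigned to this position.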